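Two limits and a third analogue on a shared core

The compounds below may be only part of what the source reports. "The series", "measured", "known", "first", "only" and "open" are said of these compounds alone.

compound 1, `CC1CC/C(=N\Nc2ccc(I)cc2)c2ncc(C(=O)O)c(=O)n21`, a limit only: > 1000 umol/kg
compound 2, `CC1CC/C(=N\Nc2ccccc2O)c2ncc(C(=O)O)c(=O)n21`, a limit only: > 100 umol/kg

In a functional assay on the whole organism for inhibition, with Rattus norvegicus as the target (on this read-out lower numbers stand for an effect already at smaller amounts and higher numbers for an effect only at larger amounts of compound), compound 1 reaches no number but a limit, > 1000 umol/kg. In the same read-out compound 2 also stops at a limit, > 100 umol/kg. Going by the values given here, the one measured step, a step that the two limits leave unreadable from compound 1 to compound 2, therefore cannot be read in size or direction; the two values sit at the limit of > 100 umol/kg in this assay, at which 1 of the 2 values shown sits, and at the limit of > 1000 umol/kg in this assay, at which 1 of the 2 values shown sits, and nothing further is known about either compound.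

Compound 3, `CC1CC/C(=N\Nc2ccc(O)cc2)c2ncc(C(=O)O)c(=O)n21`, differs from compound 2 in one place: 4-hydroxyphenyl in place of 2-hydroxyphenyl on an amine nitrogen. Among the compounds with values here, no measured step bears on this change, since the only step known joins two limits. Compound 2 thus stands at a limit with no number beneath it, and the move to compound 3 starts from that limit. The expectation for compound 3 is that the assay again reports a limit rather than a number, and the estimate is 300 umol/kg, within 100 umol/kg to 3000 umol/kg. This estimate means a step that the limit leaves unreadable from compound 2 to compound 3, expected to fall within the scatter rather than beyond it.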

Compound 3, dose for 50% inhibition: > 100 umol/kg
Compound 3: only a limit was reported; the forecaster's own chance of this, stated with the estimate: 75%; the middle value does not contradict the limit.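

Compound 3, like compound 2 and compound 1, gives only a limit in this assay, so the steps joining compound 3 to compound 2 and to compound 1 cannot be read in size or direction. The compounds shown leave open whether 4-hydroxyphenyl in place of 2-hydroxyphenyl, or hydroxy in place of iodo, changes the effect at all.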